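A nitro-bearing phenyl replaces fluorophenyl on a urea

The source may report more compounds than this note shows. Statements on the series, on what has been measured and on what is new or still open speak of the compounds shown alone.

Compound 1 `O=C(Nc1ccc(F)cc1)N[C@H]1CC[C@H](Oc2ccc(F)cc2)CC1` is a urea that carries a 4-fluorophenyl group on one nitrogen and, on the other, a cyclohexane ring bearing a 4-fluorophenoxy group. In a functional assay on CRL2813 cells (Homo sapiens) for cytotoxicity, read by sulforhodamine B assay, with a stated time of 5 days (on this read-out higher numbers stand for weaker inhibition and lower numbers for stronger inhibition), compound 1 gives 20000 nM, the highest of the three numbers measured here, so it is the weakest inhibitor of the set. Compound 2 `O=C(Nc1cccc(C(F)(F)F)c1)N[C@H]1CC[C@H](Oc2cccc(C(F)(F)F)c2)CC1` gives 1300 nM, and compound 3 `O=C(Nc1cccc(C(F)(F)F)c1)N[C@H]1CC[C@@H](Oc2ccc(F)cc2)CC1` gives 2600 nM; both lie beyond the scatter below compound 1.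

For the measured compounds named here, compound 4 `O=C(Nc1ccccc1[N+](=O)[O-])N[C@H]1CC[C@H](Oc2ccc(F)cc2)CC1` keeps the core of compound 1 and changes only one group: 2-nitrophenyl in place of 4-fluorophenyl on an amide-type nitrogen. Going by the values given here, no measured pair shows this particular change, so its effect is uncertain. Compound 2 with 1300 nM and compound 3 with 2600 nM show that different substitution of the aryl groups can lower the number well beyond the scatter, although neither carries a nitro group. The step from compound 1 to compound 4 is expected to be a 2.2-fold lower number from compound 1 to compound 4 (0.35 log units; beyond the scatter), a modest fall that may not clear the scatter. Compound 4 is therefore estimated to give 9000 nM, with a range from 2500 nM to 30000 nM.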

Compound 4, half-maximal inhibitory concentration: 3500 nM
Estimate against measurement, compound 4: 2.6-fold (0.41 log units) above, within the range that was stated.
By their numbers in this assay, from the lowest: compounds 2, 3 and 4 (each within the scatter of the next, the first and the last beyond it); then compound 1.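

In this assay, for the compounds shown here, placing 2-nitrophenyl instead of 4-fluorophenyl on the amide-type nitrogen gives a 5.7-fold lower number from compound 1 to compound 4 (0.76 log units; beyond the scatter), the first step in this set in which only one group changes. It shows that this nitrogen substituent alone can shift the number beyond the scatter while the rest of the molecule stays the same, although the size of the step is only modest. No measurement here explains why the number falls.

The compounds shown leave open whether the shift belongs to the nitro group itself or to where it sits on the phenyl ring. They also leave open how a plain phenyl, an aminophenyl or a phenyl bearing a carboxylic acid would compare on this same nitrogen, with the rest of compound 1 kept.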